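The source may report more compounds than this note shows. Statements on the series, on what has been measured and on what is new or still open speak of the compounds shown alone.

Measured so far in a functional assay on PANC-1 cells (Homo sapiens) for inhibition, read by MTT assay, with a stated time of 24 h, tested at 10 uM; on this read-out higher numbers stand for more inhibition at the one concentration tested (going by the name of the read-out) and lower numbers for less inhibition:
Compound 1 `CC(C)=CCC1Cc2c(OCCCNS(=O)(=O)c3ccc(C(F)(F)F)cc3)cc(=O)n(CCCO)c2CC1(C)C`: 29.6%
Compound 2 `CC(C)=CCC1Cc2c(OCCCNS(=O)(=O)c3ccc([N+](=O)[O-])cc3)cc(=O)n(CCCO)c2CC1(C)C`: 47.7%

Within the data shown here, of the two numbers, compound 2 stands highest in this assay; the only other compound, compound 1, lies below it by a step beyond the scatter, a number 18.1 percentage points higher from compound 1 to compound 2 (beyond the scatter), a modest change brought by a nitro in place of a trifluoromethyl on the aromatic carbon.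

Compound 3 `CC(C)=CCC1Cc2c(OCCCNC(=O)c3ccc([N+](=O)[O-])cc3)cc(=O)n(CCCO)c2CC1(C)C` differs from compound 2 in one place: (4-nitrophenyl)carbonyl in place of (4-nitrophenyl)sulfonyl on an amine nitrogen. Among the measured compounds shown here, no measured step bears directly on this change. For the measured compounds named here, the single step that exists, a number 18.1 percentage points higher from compound 1 to compound 2 (beyond the scatter), concerns the substituent on the aromatic ring and leaves the sulfonyl link to the amine nitrogen untouched, so it gives no guide to swapping that sulfonyl for a carbonyl. With nothing to anchor a direction, the expectation is a step of no size beyond the scatter, a number 2.7 percentage points lower from compound 2 to compound 3 (within the scatter), though with wide uncertainty. Compound 3 is therefore estimated at 45%, with a range from 20% to 70%.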

Compound 3, a percentage reported as inhibition, at one concentration (the size of the read-out at that concentration, not a potency): 49.9%
Compound 3: the middle estimate sits 4.9 percentage points below what was measured; measured number inside the range.
By their numbers in this assay, from the lowest: compound 1; then compounds 2 and 3 (each within the scatter of the next).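

In this assay, (4-nitrophenyl)carbonyl in place of (4-nitrophenyl)sulfonyl on the amine nitrogen gives a number 2.2 percentage points higher from compound 2 to compound 3 (within the scatter). Among these compounds, the earlier compounds varied only the group on the aromatic ring, so this is the first sign that the link on the amine nitrogen can be exchanged without a step beyond the scatter, at least with the nitro group on the ring. Nothing available accounts for this result.

On these data alone, it remains open whether the step seen between trifluoromethyl and nitro on the sulfonyl link also holds on the carbonyl link. The compounds shown also leave open what a urea or a plain methylene link on that nitrogen would give, or an amine or a carboxylic acid in place of the nitro group.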